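Fluoro to trifluoromethyl: expecting little change in cytotoxicity

The source may report more compounds than this note shows. Statements on the series, on what has been measured and on what is new or still open speak of the compounds shown alone.

Measured so far in an ADME assay on MT4 cells (Homo sapiens) for cytotoxicity, read by MTT assay, with a stated time of 4 days; on this read-out higher numbers stand for lower toxicity in this test and lower numbers for higher toxicity in this test:
compound 1 `Nc1ccc2oc(-c3cccc(C(F)(F)F)c3)cc(=O)c2c1` gives 138000 nM
compound 2 `Nc1ccc2oc(-c3ccccc3)c(O)c(=O)c2c1` gives 217000 nM
compound 3 `Nc1ccc2oc(-c3cccc(F)c3)c(O)c(=O)c2c1` gives 35300 nM

Compound 3 has the lowest of these three numbers, and its gaps to compound 1 and compound 2 both lie beyond the scatter. The next analogue, compound 4 `Nc1ccc2oc(-c3cccc(C(F)(F)F)c3)c(O)c(=O)c2c1`, has not yet been measured. It carries trifluoromethyl in place of fluoro on an aromatic carbon. Within the data shown here, the only measured step of one change is a 6.1-fold lower number from compound 2 to compound 3 (0.79 log units; beyond the scatter), where fluoro replaced hydrogen on an aromatic carbon. That modest step does not measure the exchange of fluoro for trifluoromethyl. Compound 4 also differs elsewhere from compound 1, which carries trifluoromethyl and gives 138000 nM, a higher number than that of compound 3. The data therefore point to no firm direction in this assay, and no step beyond the scatter is expected. The expected change is a 1.3-fold higher number from compound 3 to compound 4 (0.11 log units; within the scatter). For compound 4 the estimated value is 45000 nM, with an expected range from 15000 nM to 130000 nM.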

Compound 4, half-maximal cytotoxic concentration: 8100 nM
Beside the measured number, compound 4's estimate is 5.6-fold (0.74 log units) above it, and the stated range ends above it.
By their numbers in this assay, from the lowest: compound 4; then compound 3; then compounds 1 and 2 (each within the scatter of the next).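

In this assay, trifluoromethyl in place of fluoro on the aromatic carbon gives a 4.4-fold lower number from compound 3 to compound 4 (0.64 log units; beyond the scatter) and so counts as a real step in its own right, and trifluoromethyl in place of hydrogen at the same carbon gives a 27-fold lower number from compound 2 to compound 4 (1.43 log units; beyond the scatter) as the largest change at this position among these compounds, which puts hydrogen, fluoro and trifluoromethyl in order of falling numbers, meaning higher toxicity in this test. Trifluoromethyl does not set the number alone, since gaining a hydroxy group gives a 17-fold lower number from compound 1 to compound 4 (1.23 log units; beyond the scatter) with trifluoromethyl present on both sides of the step. Nothing available explains these steps.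

As far as these compounds go, whether an amine, a nitrile or a longer chain at this carbon would extend the order stays open. Also open, from the compounds shown here alone, is whether the step from fluoro to trifluoromethyl depends on the hydroxy group.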